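Stripping the Amide Aryl Group Down to Plain Phenyl

This account rests on a few compounds, and the source may have more. Where it says the series, first, only, none or still open, it means among the compounds named here.

Compound 3 `COc1cc(-c2nn(-c3cccc(NC(=O)c4ccc(Cl)c(C(F)(F)F)c4)c3)cc2-c2ccncc2)ccc1Cl` belongs to a set of three close analogues that share one core and differ only in the group attached to the amide-type nitrogen. In a functional assay on CAKI-1 cells (Homo sapiens) for inhibition, read by sulforhodamine B assay, with a stated time of 48 h (a lower number here means that less compound is tolerated, a higher number that more compound is tolerated), compound 3 reaches only a limit, > 32500 nM. Compound 1 `COc1cc(-c2nn(-c3cccc(NC(=O)Nc4cc(C(F)(F)F)cc(C(F)(F)F)c4)c3)cc2-c2ccncc2)ccc1Cl` gives 49300 nM in this assay. Compound 2 `COc1cc(-c2nn(-c3cccc(NC(=O)Nc4cccc(C(F)(F)F)c4)c3)cc2-c2ccncc2)ccc1Cl` likewise reaches only a limit, > 50000 nM. Neither step among them can be sized: an at least 1.0-fold higher number from compound 1 to compound 2 (0.00 log units; that floor lies within the scatter) and a step that the two limits leave unreadable from compound 2 to compound 3 both end at a limit, as the limit of > 32500 nM in this assay, at which 1 of the 3 values shown sits, and the limit of > 50000 nM in this assay, at which 1 of the 3 values shown sits, show. Compound 4 `COc1cc(-c2nn(-c3cccc(NC(=O)c4ccccc4)c3)cc2-c2ccncc2)ccc1Cl` is the unmeasured analogue; it arises from compound 3 by phenyl in place of 4-chloro-3-(trifluoromethyl)phenyl on a carbonyl carbon. Every measured compound sits at or near the top of what this assay can report, and the one measured loss of a trifluoromethyl produced no readable shift. The same outcome is expected here: a step that the limit leaves unreadable from compound 3 to compound 4 is estimated to be no step beyond the scatter. In this assay compound 4 is expected to give about 50000 nM, most plausibly between 25000 nM and 100000 nM, and probably again only as a limit.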

Compound 4, concentration lethal to 50% of the cells: > 100000 nM
Compound 4 gave a limit, no number; the forecaster's own chance of this, stated with the estimate: 75%; middle value at least 2.0-fold (0.30 log units) from the limit.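

In this assay compound 4 reaches only a limit, > 100000 nM, so its steps from compound 3 and from compound 2 cannot be read. The compounds shown leave open whether phenyl in place of 4-chloro-3-(trifluoromethyl)phenyl on the carbonyl carbon shifts this read-out at all.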